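Aryl swap on the triazole of compound 2

The source may report more compounds than this note shows. Statements on the series, on what has been measured and on what is new or still open speak of the compounds shown alone.

The series is read in a functional assay on HeLa cells (Homo sapiens) for antiproliferative activity, read by MTT assay, with a stated time of 72 h; a higher number here means a weaker inhibitor, a lower number a stronger inhibitor. Compound 2 `CCCCCc1ccc(C#Cc2c(-c3ccc(CCCCC)cc3)oc3nc(=O)n(Cc4cn(-c5ccccc5F)nn4)cc23)cc1` gives 9000 nM. Compound 1 `O=c1nc2oc(C3CC3)c(C#CC3CC3)c2cn1Cc1cn(-c2ccccc2F)nn1` gives 51200 nM, the higher of the two numbers, and the gap from compound 1 to compound 2 lies beyond the scatter. Compound 3 `CCCCCCc1cc2cn(Cc3cn(-c4ccccc4F)nn3)c(=O)nc2o1` returns only a limit of the assay, > 100000 nM. The same point is recorded as the limit of > 100000 nM in this assay, at which 1 of the 3 values shown sits. Compound 2 therefore stands lowest of the two numbers shown.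

Compound 4 `CCCCCc1ccc(C#Cc2c(-c3ccc(CCCCC)cc3)oc3nc(=O)n(Cc4cn(-c5ccc(Cl)cc5)nn4)cc23)cc1` is not yet measured. It differs from compound 2 by 4-chlorophenyl in place of 2-fluorophenyl on an aromatic nitrogen. Among the measured compounds shown here, no measured pair carries this same change, so no step is known for it; the shared core of compound 2 is untouched. The expected step of a 1.1-fold lower number from compound 2 to compound 4 (0.05 log units; within the scatter) is small and not clearly beyond the scatter in either direction. Compound 4 is expected at 8000 nM, with a range from 3000 nM to 25000 nM.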

Compound 4, half-maximal inhibitory concentration: > 100000 nM
Compound 4 gave a limit, no number; the forecaster's own chance of this, stated with the estimate: 10%; middle value at least 12-fold (1.09 log units) away from the limit.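

In this assay the aryl group on the triazole nitrogen proves to matter: 4-chlorophenyl in place of 2-fluorophenyl gives an at least 11-fold higher number from compound 2 to compound 4 (1.04 log units; beyond the scatter). Among the compounds shown here, all the earlier compounds carry 2-fluorophenyl, so they varied only the other groups, whereas this pair reads the aryl group alone with the shared core untouched. The new result is a limit and not a number, so the true size of the step stays unknown, and compound 4 joins compound 3 at that limit: the limit of > 100000 nM in this assay, at which 2 of the 4 values shown sit.

The halogen and its place on the ring change together in this one step, and the compounds shown do not separate the two. Going by these compounds, the effect of 2-chlorophenyl, 4-fluorophenyl or an unsubstituted phenyl on the triazole nitrogen remains open, as does that of an amine on this ring.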